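Replacing Cyclopropyl on the Amide Nitrogen of Compound 1

The source may hold more compounds than are shown below. What is called first, only, known or untested is meant among the compounds shown, and "the series" means these compounds.

Compound 1 `CNC(=O)c1cc(C(=O)NC2CC2)cc2c1OC[C@@]2(C)c1ccccc1` gives 4 in a physicochemical assay for lipophilicity, at pH 7.4 (a lower number here means a more polar compound, a higher number a more lipophilic compound), the highest of the three numbers recorded so far. Compound 3 `CNC(=O)c1cc(C(=O)NC2CC2)cc2c1OC[C@H]2c1cccc(F)c1` gives 3.7 in this assay, a value within the usual scatter of that of compound 1. Compound 2 `CNC(=O)c1cc(C(N)=O)cc2c1O[C@H](CF)[C@H]2c1ccccc1` gives 2.9 in this assay, and its gap from compound 1 lies beyond the scatter. Compound 4 `CNC(=O)c1cc(C(=O)N[C@H]2[C@@H]3COC[C@@H]32)cc2c1OC[C@@]2(C)c1ccccc1` has not yet been measured. It differs from compound 1 in one place: a group of 6 heavy atoms (5 carbon, 1 oxygen; one three-membered non-aromatic ring of carbon only, one five-membered non-aromatic ring with 1 hetero atom) in place of a group of 3 heavy atoms (3 carbon; one three-membered non-aromatic ring of carbon only), on an amide-type nitrogen. The entering group carries one hydrogen-bond acceptor where the cyclopropyl carried none. A modest downward step is expected, one that may still fall within the scatter; the step from compound 1 to compound 4 in this assay is estimated at a number 0.40 log units lower from compound 1 to compound 4 (beyond the scatter). Compound 4 is expected to give 3.6 in this assay, with a range from 3 to 4.2.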

Compound 4, distribution coefficient: 3.7
For compound 4 the middle estimate is 0.10 log units below the measured one; low and high end bracket the measured number.
By their numbers in this assay, from the lowest: compound 2; then compounds 3, 4 and 1 (each within the scatter of the next).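

This is the first step shown at this position: in this assay, exchanging the cyclopropyl on the amide-type nitrogen for the group of 6 heavy atoms, which carries one hydrogen-bond acceptor, gives a step of a number 0.30 log units lower from compound 1 to compound 4 (within the scatter). The amide-type nitrogen thus accepts this larger group with no shift beyond the scatter. Nothing available explains the size of this step. The compounds shown leave open what a group bearing an amine or a carboxylic acid would give on this nitrogen, and whether the same exchange would give a similar step on another core.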